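A few compounds are considered here, and "the series" means these few. Any claim that something is new, unique, unknown or untested is made for them only; others in the source may bear on it.

In a functional assay on HGC cells (Homo sapiens) for cytotoxicity, read by MTT assay, with a stated time of 48 h (on this read-out lower numbers stand for stronger inhibition and higher numbers for weaker inhibition), compound 1, whose structure is `CCn1c(/C=C2/C(=O)Nc3ccc(C)cc32)nc2ccccc21`, gives > 50000 nM; this is a limit of the assay, not a measured number, so compound 1 stands at the weak end of what can be reported. Two further compounds share its core. Compound 2, with structure `CC(C)n1c(/C=C2/C(=O)Nc3ccc(Cl)cc32)nc2ccccc21`, gives 32800 nM in this assay, and compound 3, with structure `Cn1c(/C=C2/C(=O)Nc3ccc(Cl)cc32)nc2ccccc21`, gives 43600 nM. Among the compounds with values here, the only measured step between them, a 1.3-fold higher number from compound 2 to compound 3 (0.12 log units; within the scatter), concerns the group on the aromatic nitrogen and not the group that changes here.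

Compound 4, with structure `CCn1c(/C=C2/C(=O)Nc3ccc([N+](=O)[O-])cc32)nc2ccccc21`, differs from compound 1 by nitro in place of methyl on an aromatic carbon. No measured step touches this exchange of methyl for nitro, so none of the steps shown bears directly on it. What the numbers do show is that compound 1 sits at the limit of > 50000 nM in this assay, at which 1 of the 3 values shown sits, and that compounds 2 and 3, which carry a chlorine in place of the methyl, give numbers inside the measurable range.

On this basis compound 4 is expected to land near the values of compounds 2 and 3, as an estimate of 38000 nM in this assay, within a range from 14000 nM to 100000 nM, which would mean an expected step of an at least 1.3-fold lower number from compound 1 to compound 4 (0.11 log units; that floor lies within the scatter).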

Compound 4, half-maximal inhibitory concentration: > 50000 nM
Compound 4: only a limit was reported (the forecaster's own chance of this, stated with the estimate: 35%); middle value at least 1.3-fold (0.11 log units) from the limit.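

Compound 1 and compound 4 both stand at a limit of the assay rather than at a measured number, so no step between them can be read: the limit of > 50000 nM in this assay, at which 2 of the 4 values shown sit.

The compounds shown leave open how far past that limit each of the two lies, and so whether nitro in place of methyl changes cytotoxicity at all.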